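A few compounds are considered here, and "the series" means these few. Any claim that something is new, unique, unknown or untested is made for them only; others in the source may bear on it.

In a functional assay on NCI-H322M cells (Homo sapiens) for inhibition, read by sulforhodamine B assay, with a stated time of 48 h, tested at 10 uM (on this read-out higher numbers stand for more inhibition at the one concentration tested (going by the name of the read-out) and lower numbers for less inhibition), three compounds of one series have been measured. Compound 1 `O=Cc1ccc(-c2cn3ccnc3c(-c3ccc4ncn(C5CCCCC5)c4c3)n2)cc1` gives 11.2%. Compound 2 `c1ccc2c(-c3cn4ccnc4c(-c4ccc5ncn(C6CCCCC6)c5c4)n3)cccc2c1` gives 4.74%, and compound 3 `O=Cc1ccc(-c2cn3ccnc3c(-c3ccc4ncn(Cc5ccccc5)c4c3)n2)cc1` gives 11.2%. The move from compound 1 to compound 2 is the change (naphthalen-1-yl in place of 4-formylphenyl on an aromatic carbon), which brought a number 6.5 percentage points lower from compound 1 to compound 2 (within the scatter). The move from compound 1 to compound 3 is the change (benzyl in place of cyclohexyl on an aromatic nitrogen), which brought no change at the digits printed from compound 1 to compound 3 (within the scatter). Compound 3 thus stands level with compound 1 at the digits reported, and both are within the scatter of compound 2.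

Compound 4 `c1ccc(Cn2cnc3ccc(-c4nc(-c5cccc6ccccc56)cn5ccnc45)cc32)cc1` has not been measured in this assay. It differs from compound 3 by naphthalen-1-yl in place of 4-formylphenyl on an aromatic carbon, the same change already seen from compound 1 to compound 2, at a place described in the same words. The two cores differ by the change (benzyl in place of cyclohexyl on an aromatic nitrogen).

The expected step from compound 3 to compound 4 is a number 6.2 percentage points lower from compound 3 to compound 4 (within the scatter), estimated beside the earlier step, which rests on the same change having given a number 6.5 percentage points lower from compound 1 to compound 2 (within the scatter) and on compound 3 sitting level with compound 1. For compound 4 the expected inhibition is therefore about 5%, with a range from -5% to 15%.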

Compound 4, a percentage reported as inhibition, at one concentration (the size of the read-out at that concentration, not a potency): 1.34%
Estimate against measurement, compound 4: 3.7 percentage points above; the range from low to high includes it.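

In this assay, placing naphthalen-1-yl in the position of 4-formylphenyl on the core bearing benzyl gave a number 9.9 percentage points lower from compound 3 to compound 4 (within the scatter), and this agrees with the same change on the core bearing cyclohexyl: the same change on two cores in this assay, a number 6.5 percentage points lower (within the scatter) from compound 1 to compound 2 and a number 9.9 percentage points lower (within the scatter) from compound 3 to compound 4, 3.4 percentage points apart, within the scatter of two such steps. The change from cyclohexyl to benzyl on the aromatic nitrogen, made with naphthalen-1-yl in place, gave a number 3.4 percentage points lower from compound 2 to compound 4 (within the scatter), and this too agrees with its earlier counterpart: the same change on two cores in this assay, no change at the digits printed (within the scatter) from compound 1 to compound 3 and a number 3.4 percentage points lower (within the scatter) from compound 2 to compound 4, 3.4 percentage points apart, within the scatter of two such steps. For the compounds shown here, both changes therefore read alike on the two cores, but no step stands clear of the scatter, so the agreement is between steps that cannot be told from no change, and it does not show that either change has a real effect that carries from one core to the other.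

The compounds shown leave open whether an amine or a carboxylic acid on the aromatic carbon would move the inhibition clear of the scatter. They also leave open whether a longer chain on the aromatic nitrogen would do so.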